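Adding a Second Chlorine: Cytotoxicity Expected Unchanged

This account rests on a few compounds, and the source may have more. Where it says the series, first, only, none or still open, it means among the compounds named here.

Three measured compounds share one core and differ only in the group on the benzyl ring. Compound 1 `O=C(NOCc1ccccc1)c1cn(-c2ccccc2)nc1-c1ccccc1` gives 122000 nM in an ADME assay on HEK-293T cells (Homo sapiens) for antiproliferative activity, read by MTT assay, with a stated time of 48 h, in the presence of a further agent that is not named here; on this read-out lower numbers stand for higher toxicity in this test and higher numbers for lower toxicity in this test. Compound 2 `O=C(NOCc1ccccc1F)c1cn(-c2ccccc2)nc1-c1ccccc1` gives 75700 nM in this assay, and compound 3 `O=C(NOCc1ccccc1Cl)c1cn(-c2ccccc2)nc1-c1ccccc1` gives 82100 nM; all three numbers lie within the scatter of one another, so compound 3 stands apart from neither. Compound 4 `O=C(NOCc1ccccc1Cl)c1cn(-c2ccccc2)nc1-c1ccc(Cl)cc1` differs from compound 3 by chloro in place of hydrogen on an aromatic carbon. The step that bears most on this is a 1.5-fold lower number from compound 1 to compound 3 (0.17 log units; within the scatter), the same kind of exchange of a chlorine for a hydrogen, and a 1.6-fold lower number from compound 1 to compound 2 (0.21 log units; within the scatter) was as small. Only a step within the scatter is therefore expected in this assay, roughly a 1.3-fold lower number from compound 3 to compound 4 (0.10 log units; within the scatter). Compound 4 is estimated at 65000 nM, between 30000 nM and 140000 nM.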

Compound 4, half-maximal cytotoxic concentration: 129000 nM
Compound 4: the middle estimate sits 2.0-fold (0.30 log units) below what was measured; low and high end bracket the measured number.
By their numbers in this assay, from the lowest: compounds 2, 3, 1 and 4 (each within the scatter of the next).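

The change from phenyl to 4-chlorophenyl sits on a different ring from the benzyl ring varied so far, and it gives a 1.6-fold higher number from compound 3 to compound 4 (0.20 log units; within the scatter) in this assay. A chloro at this place, para to a large group, therefore leaves the read-out within the scatter, as the chloro and fluoro on the benzyl ring did. No measurement here bears on a cause.

Going by these compounds, whether an amine, a carboxylic acid or a longer chain at this place would move the number beyond the scatter stays open. Also open, on these data alone, is whether this chloro would give a similarly small step on compound 1, which has no chlorine on the benzyl ring.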